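Carboxy in place of hydroxymethyl: an open question

The source may hold more compounds than are shown below. What is called first, only, known or untested is meant among the compounds shown, and "the series" means these compounds.

Of the compounds shown here, two have so far been tested in a functional assay on Rec1 cells (Homo sapiens) for inhibition, read by luminescence and CellTiter-Glo, with a stated time of 72 h (a higher number here means a weaker inhibitor, a lower number a stronger inhibitor), and they lie far apart. Compound 2 `O=C(CCl)Nc1ccc(Cn2nc(-c3ccc(Oc4ccccc4)cc3)cc2CO)cc1` gives 400 nM and holds the lower of the two numbers, while compound 1 `C/C=C/C(=O)Nc1ccc(Cn2nc(-c3ccc(Oc4ccccc4)cc3)cc2C(=O)O)cc1` gives 23600 nM and the gap between them is beyond the scatter of repeated measurements. The next molecule is compound 3 `O=C(CCl)Nc1ccc(Cn2nc(-c3ccc(Oc4ccccc4)cc3)cc2C(=O)O)cc1`, which has carboxy in place of hydroxymethyl on an aromatic carbon and otherwise matches compound 2. Among the measured compounds shown here, no measured pair isolates this single change. For the measured compounds named here, the one guide is that compound 1, the only tested compound with a carboxy, sits at 23600 nM in this assay and so on the weaker side. However, its amide group differs from that of compound 3, so it is only a loose guide. The expected step is a 10-fold higher number from compound 2 to compound 3 (1.00 log units; beyond the scatter) towards a weaker inhibitor and beyond the scatter. For compound 3 the estimate is 4000 nM with an expected range from 1000 nM to 16000 nM in this measurement.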

Compound 3, half-maximal inhibitory concentration: 4000 nM
Estimate against measurement, compound 3: no gap at the digits printed; the range from low to high includes it.
By their numbers in this assay, from the lowest: compound 2; then compound 3; then compound 1.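

In this assay, with the rest of the molecule held fixed, replacing hydroxymethyl with carboxy on this aromatic carbon gives a 10-fold higher number from compound 2 to compound 3 (1.00 log units; beyond the scatter), the first direct sign that this position responds to the group it carries and that, of these two groups, hydroxymethyl gives the stronger inhibitor. Compound 3 also allows a second single-change comparison, this time with carboxy kept in place: chloromethyl in place of prop-1-en-1-yl on a carbonyl carbon gives a 5.9-fold lower number from compound 1 to compound 3 (0.77 log units; beyond the scatter), so a change at the amide end also moves the number beyond the scatter. Nothing available explains either step.

The compounds shown leave open how other groups would read at this aromatic carbon, such as a methyl ester, a primary amide or an aminomethyl group, and whether any of them could match hydroxymethyl. They also leave open whether hydroxymethyl would keep its advantage over carboxy when the carbonyl carbon carries prop-1-en-1-yl rather than chloromethyl.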